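The compounds below may be only part of what the source reports. "The series", "measured", "known", "first", "only" and "open" are said of these compounds alone.

Measured so far in a functional assay on HeLa cells (Homo sapiens) for inhibition, read by sulforhodamine B assay, with a stated time of 48 h; on this read-out higher numbers stand for weaker inhibition of growth and lower numbers for stronger inhibition of growth: compound 1 `O=C(/C(=C/c1ccccc1)CCl)c1ccccc1` gives 23000 nM; compound 2 `O=C(/C(=C/c1ccc(Cl)cc1)CCl)c1ccccc1` gives 22000 nM; compound 3 `CC(=O)OC/C(=C\c1ccc(Cl)cc1)C(=O)c1ccccc1` gives 3200 nM.

From compound 1 to compound 2 the change is chloro in place of hydrogen on an aromatic carbon, and it made a 1.0-fold lower number from compound 1 to compound 2 (0.02 log units; within the scatter). The next step made a 6.9-fold lower number from compound 2 to compound 3 (0.84 log units; beyond the scatter). The difference between the cores of compound 1 and compound 3 is not broken down here.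

Compound 4 `CC(=O)OC/C(=C\c1ccc(Cl)cc1Cl)C(=O)c1ccccc1` has not yet been measured. It differs from compound 3 by chloro in place of hydrogen on an aromatic carbon. This is the same kind of change as from compound 1 to compound 2, but the place is not identical: here the chloro enters ortho to a large group and meta to a chloro group, whereas before it entered para to a large group. The step from compound 3 to compound 4 is expected to be small, a 1.1-fold lower number from compound 3 to compound 4 (0.03 log units; within the scatter). That expectation rests on the earlier step of the same kind, because a 1.0-fold lower number from compound 1 to compound 2 (0.02 log units; within the scatter). Compound 4 is therefore estimated at 3000 nM, with a likely range from 1200 nM to 8000 nM.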

Compound 4, concentration for 50% growth inhibition: 16000 nM
Compound 4: middle estimate off by 5.3-fold (0.73 log units), on the low side; the measured number lies above the stated range.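

In this assay the added chloro gave a 5.0-fold higher number from compound 3 to compound 4 (0.70 log units; beyond the scatter), so this change did not carry over from one core to the other, and the two steps differ: the same change on two cores in this assay, a 1.0-fold lower number (0.02 log units; within the scatter) from compound 1 to compound 2 and a 5.0-fold higher number (0.70 log units; beyond the scatter) from compound 3 to compound 4, 5.2-fold (0.72 log units) apart, beyond the scatter of two such steps. The two steps differ in more than the core, as the chloro of compound 4 enters ortho to a large group and meta to a chloro group, a place unlike that of the earlier step. These two steps therefore cannot show whether the core or the place of the chloro accounts for the gap, and they set no rule for other cores.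

The compounds shown leave open how a lone chloro at the new place would read on either core. Also open, going by these compounds, is how the series would respond to a methoxy group or an amine on the ring, or to a longer chain in place of the acetoxy group.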